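A few compounds are considered here, and "the series" means these few. Any claim that something is new, unique, unknown or untested is made for them only; others in the source may bear on it.

Values in an ADME assay on cells (Mus musculus, strain BALB/c) for cytotoxicity, read by MTT assay, with a stated time of 24 h (a lower number here means that less compound is tolerated, a higher number that more compound is tolerated), for the measured compounds:

compound 1, `COc1cc(-c2nnc(SCc3ccc(C)cc3)o2)ccc1O`: 549000 nM
compound 2, `COc1cc(-c2nnc(SCc3ccccc3Cl)o2)ccc1O`: 564000 nM
compound 3, `COc1cccc(CSc2nnc(-c3ccc(O)c(OC)c3)o2)c1`: 389000 nM

Compound 3 holds the lowest of the three numbers, but its gaps to compound 1 and to compound 2 are both within the scatter, so no order among the three can be read from these values; all three sit in the same band of tolerated concentration.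

The change to compound 4, `COc1cc(-c2nnc(SCc3ccc(Br)cc3)o2)ccc1O`, is 4-bromophenyl in place of 3-methoxyphenyl on a saturated chain carbon bound to a sulfur. Every measured step in the series touches the same place: a 1.0-fold higher number from compound 1 to compound 2 (0.01 log units; within the scatter); a 1.4-fold lower number from compound 1 to compound 3 (0.15 log units; within the scatter); a 1.4-fold lower number from compound 2 to compound 3 (0.16 log units; within the scatter). Three different aryl groups on the saturated chain carbon bound to a sulfur have thus given numbers that do not separate beyond the scatter, and nothing in the data singles out 4-bromophenyl as likely to behave otherwise. The expectation for this assay is therefore a step of no more than the scatter, in no particular direction, with compound 4 landing in the same band as compound 1, compound 2 and compound 3.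

Compound 4 is estimated at 470000 nM, with a range from 260000 nM to 850000 nM. The step this estimate implies is expected to be a 1.2-fold higher number from compound 3 to compound 4 (0.08 log units; within the scatter).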

Compound 4, half-maximal cytotoxic concentration: 455000 nM
The estimate for compound 4 lay 1.0-fold (0.01 log units) above the measured number; the measured number falls inside the stated range.
By their numbers in this assay, from the lowest: compounds 3, 4, 1 and 2 (each within the scatter of the next).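

In this assay, 4-bromophenyl on a saturated chain carbon bound to a sulfur stays level with each earlier group: a 1.2-fold higher number from compound 3 to compound 4 (0.07 log units; within the scatter), a 1.2-fold lower number from compound 2 to compound 4 (0.09 log units; within the scatter) and a 1.2-fold lower number from compound 1 to compound 4 (0.08 log units; within the scatter). Within the data shown here, the last of these steps is the first where a single substituent is exchanged on an otherwise unchanged aryl group, bromo in place of methyl on an aromatic carbon, and the number does not separate from that of compound 1; the step from compound 3 also takes the count of hydrogen-bond acceptors in the group from 1 to 0 without a separation beyond the scatter. No supporting data bear on why these numbers stay together.

From the compounds shown here alone, all four compounds keep the shared core and an aryl group at this place, so the flatness is established only for these four aryl groups, and what an amine, a carboxylic acid or a longer chain would give here remains open. Going by these compounds, whether a change elsewhere on the shared core would move the number out of this band also remains open.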